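Dropping a Methoxy Group from a Cyanovinyl Indole Pair

The source may hold more compounds than are shown below. What is called first, only, known or untested is meant among the compounds shown, and "the series" means these compounds.

Of the compounds shown here, three have been measured in a functional assay on UACC-62 cells (Homo sapiens) for inhibition, read by sulforhodamine B assay, with a stated time of 48 h; on this read-out higher numbers stand for weaker inhibition of growth and lower numbers for stronger inhibition of growth. Compound 3 `COc1ccc(-c2[nH]c3ccc(OC)cc3c2C=C(C#N)C#N)cc1` gives 357 nM, compound 2 `COc1ccc(-c2[nH]c3ccc(OC)cc3c2/C=C(\C#N)S(=O)(=O)c2ccccc2)cc1` gives 660 nM, and compound 1 `COc1ccc2[nH]c(-c3ccccc3)c(C=C(C#N)C#N)c2c1` gives 2500 nM. Compound 1 and compound 3 differ in a single place, (hydrogen in place of methoxy on an aromatic carbon), and this change brought a 7.0-fold higher number from compound 3 to compound 1 (0.85 log units; beyond the scatter). Compound 2 and compound 3 carry the same 4-methoxyphenyl group, but the difference between their two cores is not broken down here; their values fall within the usual scatter of each other, so nothing is said about which is stronger.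

Compound 4 `COc1ccc2[nH]c(-c3ccccc3)c(/C=C(\C#N)S(=O)(=O)c3ccccc3)c2c1` has not yet been measured in this assay . It stands to compound 2 exactly as compound 1 stands to compound 3: hydrogen in place of methoxy on an aromatic carbon. The place of the change is described in the same words for both pairs, so this is the same change, and among the compounds shown it occurs twice in all, only once with a measured outcome. Resting on that single measured outcome, the expected step from compound 2 to compound 4 in this assay is a 5.3-fold higher number from compound 2 to compound 4 (0.72 log units; beyond the scatter), taken somewhat cautiously since one instance gives no sense of how reproducible the step is. Compound 4 is therefore estimated at 3500 nM, with a likely range from 1200 nM to 10000 nM.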

Compound 4, concentration for 50% growth inhibition: 3800 nM
The estimate for compound 4 lay 1.1-fold (0.04 log units) below the measured number; low and high end bracket the measured number.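

In this assay, replacing the 4-methoxyphenyl group with phenyl on the second core brought a 5.8-fold higher number from compound 2 to compound 4 (0.76 log units; beyond the scatter), so the loss of growth inhibition first seen on the dicyanovinyl core appeared again. Set side by side, the two instances of this change agree in direction and in size: the same change on two cores in this assay, a 7.0-fold higher number (0.85 log units; beyond the scatter) from compound 3 to compound 1 and a 5.8-fold higher number (0.76 log units; beyond the scatter) from compound 2 to compound 4, 1.2-fold (0.09 log units) apart, within the scatter of two such steps This shows that, among these four compounds, the methoxy group's contribution carries over from one core to the other, and that a step read on one core would have served for the other. Going by these compounds alone, it rests on only two pairs, however, and it does not show that the step would hold on any further core, nor does it show why the methoxy group matters.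

The compounds shown leave open what other groups in the same place on the phenyl ring would do, for instance a hydroxyl, an amine, a fluorine or a longer alkoxy chain, and whether any of them would match or pass the methoxy group. As far as these compounds go, all four compounds also keep the other methoxy group on the core, so what that group contributes, and whether it interacts with this change, remains open as well.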